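The compounds below may be only part of what the source reports. "The series", "measured", "known", "first", "only" and "open" are said of these compounds alone.

Compound 1 `Fc1cnc(Nc2cc3[nH]c(-c4cccc(C(F)(F)F)c4)nc3cn2)c(F)c1` — in a physicochemical assay for solubility, using the shake flask method, in simulated intestinal fluid, measured as kinetic solubility, with a stated time of 20 h, at pH 6.5 (a lower number here means a less soluble compound, a higher number a more soluble compound), compound 1 gives a limit of the assay, >= 50000 nM.
Compound 2 `FC(F)(F)c1ccc(Nc2cc3[nH]c(-c4cccc(C(F)(F)F)c4)nc3cn2)nc1` — in this assay compound 2 also gives a limit of the assay, >= 50000 nM.
Compound 3 `O=C(O)c1ccnc(Nc2cc3[nH]c(-c4cccc(C(F)(F)F)c4)nc3cn2)c1` — in this assay compound 3 gives 60000 nM.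

For the measured compounds named here, compound 3 holds the only number among the three values; the other two sit at a limit (the limit of >= 50000 nM in this assay, at which 2 of the 3 values shown sit). The steps a step that the limit leaves unreadable from compound 1 to compound 3 and a step that the limit leaves unreadable from compound 2 to compound 3 are thus unreadable in size, as is a step that the two limits leave unreadable from compound 1 to compound 2. Compound 4 `FC(F)(F)c1cccc(-c2nc3cnc(Nc4cc(-c5nnn[nH]5)ccn4)cc3[nH]2)c1` differs from compound 3 by 1H-tetrazol-5-yl in place of carboxy on an aromatic carbon. Going by the values given here, no measured step bears on a change of this kind, and the available comparisons give no readable size. The expected step in this assay is therefore none beyond the scatter, a 1.2-fold lower number from compound 3 to compound 4 (0.08 log units; within the scatter), with a fair chance that only a limit is reported. Compound 4 is estimated at 50000 nM, within 15000 nM to 150000 nM.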

Compound 4, solubility: < 5000 nM
Compound 4 gave a limit, no number (the forecaster's own chance of this, stated with the estimate: 50%); at least 10-fold (1.00 log units) between middle value and limit.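

In this assay, 1H-tetrazol-5-yl in place of carboxy, on the aromatic carbon opposite the ring nitrogen, gives an at least 12-fold lower number from compound 3 to compound 4 (1.07 log units; beyond the scatter). For the compounds shown here, the earlier steps cannot be read, so this is the first readable sign that the group at this place can move the read-out. The value of compound 4 is a limit, not a number, so only a minimum size is known for this step: the limit of < 5000 nM in this assay, at which 1 of the 4 values shown sits.

From the compounds shown here alone, whether a primary amide or a sulfonamide at this place would read like compound 3 or like compound 4 stays open. Going by these compounds, how far compound 4 lies past its limit also stays open.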